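Methylsulfanyl for Bromo on the Core of Compound 1

The source may report more compounds than this note shows. Statements on the series, on what has been measured and on what is new or still open speak of the compounds shown alone.

Measured compounds:
compound 1 `O=C(O)c1cccc(C2=C(c3cc(Br)ccc3OCc3ccccc3)CCC2)c1` 12.6 nM
compound 2 `O=C(O)c1cccc(C2=C(c3cc(Br)ccc3OCc3ccc(F)cc3F)CCC2)c1` 5.01 nM
compound 3 `O=C(O)c1cncc(C2=C(c3cc(Cl)ccc3OCc3ccc(F)cc3F)CCC2)n1` 2 nM

In an assay on isolated protein for inhibition of prostaglandin E2 receptor EP1 subtype (Homo sapiens) (a lower number here means a stronger inhibitor, a higher number a weaker inhibitor), compound 1 gives 12.6 nM, the highest of the three numbers. Compound 2 lies nearest to it, and the step of a 2.5-fold lower number from compound 1 to compound 2 (0.40 log units; beyond the scatter) came from putting 2,4-difluorophenyl in place of phenyl on a saturated chain carbon bound to an oxygen on an aromatic ring. Within the data shown here, compound 3, which shares the 2,4-difluorophenyl, gives 2 nM, the furthest of the three from compound 1, but it differs from compound 2 in more than one place, so no single step is written for that pair.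

Compound 4 `CSc1ccc(OCc2ccccc2)c(C2=C(c3cccc(C(=O)O)c3)CCC2)c1` is not yet measured. It differs from compound 1 by methylsulfanyl in place of bromo on an aromatic carbon. Among the measured compounds shown here, no measured step touches this position; the only written step concerns the benzyloxy group, not the aromatic carbon that carries the bromo. With nothing to guide direction, the expected step of a 1.2-fold higher number from compound 1 to compound 4 (0.08 log units; within the scatter) in this assay is small, most likely within the scatter. Compound 4 is therefore estimated at 15 nM, with a range from 5 nM to 50 nM.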

Compound 4, half-maximal inhibitory concentration: 63.1 nM
Compound 4: the middle estimate sits 4.2-fold (0.62 log units) below what was measured, outside the stated range (above it).
By their numbers in this assay, from the lowest: compound 3; then compound 2; then compound 1; then compound 4.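

On the aromatic carbon para to the benzyloxy group, the position proves sensitive in this assay: methylsulfanyl in place of bromo gives a 5.0-fold higher number from compound 1 to compound 4 (0.70 log units; beyond the scatter). This is the first single change shown at this carbon, and it runs in the opposite direction to the one earlier step, which concerned the benzyloxy group and gave a lower number. No measurement shown gives a reason for this step.

The compounds shown leave open whether a methyl, a methoxy or a nitrile on the same aromatic carbon of compound 1 would give a number closer to that of the bromo or of the methylsulfanyl. They also leave open whether methylsulfanyl would raise the number to a similar extent with the 2,4-difluorophenyl of compound 2 in place.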